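Allyl for isopropyl on the benzylic carbon of compound 2

The source may report more compounds than this note shows. Statements on the series, on what has been measured and on what is new or still open speak of the compounds shown alone.

Measured compounds:
compound 1, `CCCC(NC(=O)c1nccs1)c1cnc(Nc2ccc(C)nc2)c(Cl)c1`, 28.7 nM
compound 2, `Cc1ccc(Nc2ncc([C@H](NC(=O)c3nccs3)C(C)C)cc2Cl)cn1`, 7.5 nM

Compound 2 holds the lowest of the two numbers in a functional assay on HEK293 cells for negative allosteric modulation of metabotropic glutamate receptor 5 (Homo sapiens), read by HTRF and inositol phosphate accumulation; on this read-out lower numbers stand for stronger inhibition and higher numbers for weaker inhibition. In this assay compound 1 gives 28.7 nM, and in this assay compound 2 gives 7.5 nM, a gap that lies beyond the scatter of repeated measurements.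

Compound 3, `C=CC[C@@H](NC(=O)c1nccs1)c1cnc(Nc2ccc(C)nc2)c(Cl)c1`, is not yet measured. It differs from compound 2 in one place: allyl in place of isopropyl on a saturated chain carbon bound to an amide-type nitrogen and an aromatic carbon. For the measured compounds named here, no measured pair shows this exact change. Going by the values given here, the only guide is that compound 1, which carries a linear three-carbon chain, gives 28.7 nM, so the expected step from compound 2 to compound 3 is estimated as a modest rise, a 1.9-fold higher number from compound 2 to compound 3 (0.27 log units; within the scatter), possibly only within the scatter. On that basis compound 3 is expected to give about 14 nM in this assay, with a range from 5 nM to 40 nM.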

Compound 3, half-maximal inhibitory concentration: 2.4 nM
Beside the measured number, compound 3's estimate is 5.8-fold (0.77 log units) above it; the measured number lies below the stated range.
By their numbers in this assay, from the lowest: compound 3; then compound 2; then compound 1.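

In this assay, allyl in place of isopropyl on a saturated chain carbon bound to an amide-type nitrogen and an aromatic carbon gives a 3.1-fold lower number from compound 2 to compound 3 (0.49 log units; beyond the scatter). This position therefore responds to a change that leaves the count of heavy atoms, the hydrogen-bond donors and acceptors and the net charge as they were; among the counted features, only the double bond outside aromatic rings is new. Nothing available here accounts for the size or direction of this step.

The compounds shown leave open whether the step follows from the double bond itself or from the loss of the isopropyl branch. They also leave open how a propargyl group, a cyclopropylmethyl group or a longer chain would behave on this carbon.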